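This account rests on a few compounds, and the source may have more. Where it says the series, first, only, none or still open, it means among the compounds named here.

Measured so far in a physicochemical assay for solubility, using the shake flask method, with a stated time of 12 h; a higher number here means a more soluble compound, a lower number a less soluble compound:

compound 1, `O=C(/C=C/c1ccccc1O)CC(=O)/C=C/c1cc(O)ccc1O`: 4400 nM
compound 2, `O=C(/C=C/c1cccc(O)c1)CC(=O)/C=C/c1cc(O)ccc1O`: 5800 nM
compound 3, `O=C(/C=C/c1ccccc1O)CC(=O)c1ccc(O)c(O)c1`: 77000 nM

Compound 1 and compound 2 share one core and differ in a single place: 3-hydroxyphenyl in place of 2-hydroxyphenyl on a double-bonded chain carbon bound to a double-bonded chain carbon. The step between them, a 1.3-fold higher number from compound 1 to compound 2 (0.12 log units; within the scatter), lies within the scatter, so the two values are read as equal within the repeatability of this assay.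

Compound 3 carries a different core. How its core differs from that of compound 1 is not broken down here. What the values show is that compound 3 has the highest number of the three, and that its gaps to compound 1 and to compound 2 both lie beyond the scatter.

Compound 4, `O=C(/C=C/c1cccc(O)c1)CC(=O)c1ccc(O)c(O)c1`, has not yet been measured. It differs from compound 3 in one place: 3-hydroxyphenyl in place of 2-hydroxyphenyl on a double-bonded chain carbon bound to a double-bonded chain carbon. The place is given in the same words for both pairs, so this is the same change as that from compound 1 to compound 2, now made on the core of compound 3. The step is expected to be a 1.2-fold higher number from compound 3 to compound 4 (0.07 log units; within the scatter), close to the step of a 1.3-fold higher number from compound 1 to compound 2 (0.12 log units; within the scatter), because that step sat within the scatter. From the compounds shown here alone, whether the change behaves the same on the second core is unknown, so a wider range is allowed. Compound 4 is estimated at 90000 nM in this assay, expected to fall between 40000 nM and 200000 nM.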

Compound 4, solubility: 25000 nM
Compound 4: the middle estimate sits 3.6-fold (0.56 log units) above what was measured; the whole stated range lies above it.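

On the core of compound 3, 3-hydroxyphenyl in place of 2-hydroxyphenyl, on a double-bonded chain carbon bound to a double-bonded chain carbon, gives a 3.1-fold lower number from compound 3 to compound 4 (0.49 log units; beyond the scatter) in this assay, a modest step, whereas the same change on the core of compound 1 gives a 1.3-fold higher number from compound 1 to compound 2 (0.12 log units; within the scatter). The change therefore cannot be carried from one core to the other in this series by assuming the same step: a result that lay within the scatter on the first core does not hold on the second, and here the number falls. Among these compounds, this rests on only two matched pairs, so it shows that the step depends on the core in these four compounds, but not which feature of the core is responsible, and no measurement at hand bears on the reason.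

The compounds shown leave open how the step would read on any further core, and so whether the core of compound 1 or that of compound 3 is the more typical case. They also leave open how this assay would respond if an amine or a carboxylic acid stood in place of the hydroxyphenyl groups at this same place, on either core.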